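Permeability notes on an isoxazole ether acid series

This account rests on a few compounds, and the source may have more. Where it says the series, first, only, none or still open, it means among the compounds named here.

Measured so far:
compound 1 `Cc1cc(OCc2c(-c3c(Cl)ccc(=O)n3C)noc2C(C)C)ccc1-c1ccc2c(C(=O)O)cn(C)c2c1` — "not active" (no number reported)
compound 2 `CC(C)c1onc(-c2c(Cl)cncc2Cl)c1COc1ccc(/C=C/c2cccc(C(=O)O)c2)c(Cl)c1` — 0.09 10^-6 cm/s

Compound 1 gives no single number in an ADME assay for permeability, using PAMPA; a lower number here means that the compound crosses the layer more slowly, a higher number that the compound crosses the layer faster; it is reported only as "not active" (no number reported). Compound 2 , a different acid built around the same isoxazole ether, gives 0.09 10^-6 cm/s in this assay, a low reading. Among the compounds with values here, no pair of measured compounds differs in one place, so no step size is known.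

Compound 3 `Cc1cc(OCc2c(-c3c(Cl)cn(C)c(=O)c3Cl)noc2C(C)C)ccc1-c1ccc2c(C(=O)O)cn(C)c2c1` is the next member. It differs from compound 1 by a group of 10 heavy atoms (6 carbon, 1 nitrogen, 1 oxygen, 2 chlorine; one six-membered aromatic ring with 1 hetero atom) in place of a group of 9 heavy atoms (6 carbon, 1 nitrogen, 1 oxygen, 1 chlorine; one six-membered aromatic ring with 1 hetero atom), on an aromatic carbon. With compound 1 giving no number and compound 2 standing low, the expectation for compound 3 rests on little. Compound 3 is expected to stay at the low end, and the risk that this assay again returns no number is real. The estimate for compound 3 is 0.1 10^-6 cm/s, expected to fall between 0.02 10^-6 cm/s and 0.5 10^-6 cm/s.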

Compound 3, apparent permeability: "not active" (no number reported)
Nothing numeric was reported for compound 3, and the estimate cannot be compared.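

In this assay compound 1 gives "not active" (no number reported) and compound 3 gives "not active" (no number reported), so no step can be read between them. No supporting evidence bears on this result. The compounds shown leave open whether exchanging the group of 9 heavy atoms for the group of 10 heavy atoms changes the reading in this assay at all.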